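A 4-methylbenzyl group on sulfur, starting from a limit

The source may report more compounds than this note shows. Statements on the series, on what has been measured and on what is new or still open speak of the compounds shown alone.

In a functional assay on PC-3 cells (Homo sapiens) for inhibition, read by MTT assay, with a stated time of 48 h (on this read-out higher numbers stand for weaker inhibition and lower numbers for stronger inhibition), compound 3 `COc1cc(-c2nnc(S)n2-c2ccc(N(C)C)cc2)cc(OC)c1OC` gives > 60000 nM, which is a limit and not a number. Compound 1 `COc1ccc(-n2c(S)nnc2-c2cc(OC)c(OC)c(OC)c2)cc1` gives > 60000 nM, also a limit. Compound 2 `COc1ccc(-n2c(SCC(=O)c3ccccc3)nnc2-c2cc(OC)c(OC)c(OC)c2)cc1` gives > 60000 nM, again a limit. Among the compounds with values here, the series so far therefore rests on (the limit of > 60000 nM in this assay, at which 3 of the 3 values shown sit).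

Compound 4 `COc1cc(-c2nnc(SCc3ccc(C)cc3)n2-c2ccc(N(C)C)cc2)cc(OC)c1OC` carries 4-methylbenzyl in place of hydrogen on a sulfur of compound 3. The counted change is 4-methylbenzyl in place of hydrogen on a sulfur.

Within the data shown here, the closest precedent is a step that the two limits leave unreadable from compound 1 to compound 2, where benzoylmethyl enters on that same kind of sulfur. The other measured change is a step that the two limits leave unreadable from compound 1 to compound 3, with dimethylamino in place of methoxy on an aromatic carbon. Neither gives a size to carry over, so the data support no firm direction. Only a modest gain in this assay seems plausible, and staying at the limit is about as likely.

The estimate amounts to an expected at least 1.7-fold lower number from compound 3 to compound 4 (0.23 log units; that floor lies within the scatter). Compound 4 is expected near 35000 nM, with an estimated range of 6000 nM to 60000 nM.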

Compound 4, half-maximal inhibitory concentration: 37300 nM
Estimate against measurement, compound 4: 1.1-fold (0.03 log units) below; low and high end bracket the measured number.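

In this assay compound 4 is the first compound shown to give a true number rather than a limit, so a 4-methylbenzyl group on this sulfur brings the dimethylamino compound into the range the assay can read. The step reads an at least 1.6-fold lower number from compound 3 to compound 4 (0.20 log units; that floor lies within the scatter) and its true size could be larger, but the part that can be stated is small. The steps from compound 1 to compound 2 and from compound 1 to compound 3 still cannot be read, and most of the series rests on a single boundary: the limit of > 60000 nM in this assay, at which 3 of the 4 values shown sit.

As far as these compounds go, it remains open whether a plain benzyl group or a longer alkyl chain on the same sulfur would serve as well as 4-methylbenzyl. Also open, from the compounds shown here alone, is whether a carboxylic acid or an amine at the end of that sulfur substituent would shift the number further.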